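This account rests on a few compounds, and the source may have more. Where it says the series, first, only, none or still open, it means among the compounds named here.

Measured compounds:
Compound 1 `COc1ccc(-c2nn3cc(-c4cccc(N)c4)nc3s2)cc1OC`: 13000 nM
Compound 2 `COc1cccc(-c2nn3cc(-c4cccc(N)c4)nc3s2)c1`: 29000 nM
Compound 3 `C=C(Br)C(=O)Nc1cccc(-c2cn3nc(CCc4ccccc4)sc3n2)c1`: 2600 nM

In a functional assay on FM3A cells (Mus musculus) for inhibition, read by cell counting, with a stated time of 2 days (on this read-out lower numbers stand for stronger inhibition and higher numbers for weaker inhibition), compound 3 stands lowest of the three numbers; compound 1 is nearest with 13000 nM, and compound 2 is furthest with 29000 nM. Compound 4 `C=C(Br)C(=O)Nc1cccc(-c2cn3nc(Cc4ccc(Cl)cc4)sc3n2)c1` differs from compound 3 by 4-chlorophenyl in place of benzyl on a saturated chain carbon bound to an aromatic carbon. Going by the values given here, the only measured step, a 2.2-fold higher number from compound 1 to compound 2 (0.35 log units; beyond the scatter), concerns a methoxy on a different part of the molecule and does not bear on this change. Among the compounds with values here, no step touching the phenethyl chain is available, so the expectation rests on compound 3 alone. Compound 4 is therefore expected near 2600 nM, within 900 nM to 7500 nM. Compound 4 is thus expected to show a step of no change at the digits printed from compound 3 to compound 4 (within the scatter) that lies within the usual scatter in this assay.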

Compound 4, half-maximal inhibitory concentration: 1100 nM
The estimate for compound 4 lay 2.4-fold (0.37 log units) above the measured number; the measured number falls inside the stated range.
By their numbers in this assay, from the lowest: compound 4; then compound 3; then compound 1; then compound 2.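

At the saturated chain carbon bound to an aromatic carbon, changing phenethyl to 4-chlorobenzyl in this assay gives a 2.4-fold lower number from compound 3 to compound 4 (0.37 log units; beyond the scatter), the first sign that this side of the molecule affects the read-out. The chain shortens and the chlorine enters in the same step, so this single comparison cannot separate their contributions. No supporting measurement bears on why the number moved. The compounds shown leave open how plain benzyl, with no chlorine, would compare, and whether a 4-methoxybenzyl or an aminomethyl group would be tolerated here.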